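Aryl exchange at the chain carbon: compound 1 to compound 4

The source may hold more compounds than are shown below. What is called first, only, known or untested is meant among the compounds shown, and "the series" means these compounds.

Of the compounds shown here, three have been measured in a functional assay on Raji cells (Homo sapiens) for cytotoxicity, read by MTT assay, with a stated time of 48 h; a lower number here means a stronger inhibitor, a higher number a weaker inhibitor. Compound 1 `N#Cc1ccc(Cn2c(/C=C3\SC(=S)N(CC(=O)O)C3=O)nc3ccccc32)cc1` carries 4-cyanophenyl on a saturated chain carbon bound to an aromatic nitrogen, and in this assay compound 1 gives 9780 nM, the highest of the three numbers. In this assay compound 2 `O=C(O)CN1C(=O)/C(=C/c2nc3ccccc3n2Cc2ccccc2F)SC1=S` gives 1230 nM and compound 3 `O=C(O)CN1C(=O)/C(=C/c2nc3ccccc3n2Cc2ccc(F)c(F)c2)SC1=S` gives 7250 nM. The exchange to 2-fluorophenyl produced an 8.0-fold lower number from compound 1 to compound 2 (0.90 log units; beyond the scatter), whereas the exchange to 3,4-difluorophenyl produced a 1.3-fold lower number from compound 1 to compound 3 (0.13 log units; within the scatter); between the two fluorinated analogues the step is a 5.9-fold higher number from compound 2 to compound 3 (0.77 log units; beyond the scatter).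

Compound 4 `COc1cc(Cn2c(/C=C3\SC(=S)N(CC(=O)O)C3=O)nc3ccccc32)cc(OC)c1` has not yet been measured. It differs from compound 1 as follows: 3,5-dimethoxyphenyl in place of 4-cyanophenyl on a saturated chain carbon bound to an aromatic nitrogen. Both measured steps from compound 1 replace the same 4-cyanophenyl at the same place and therefore bear on this change, but neither involves methoxy groups; one gave a modest gain, the other nothing beyond the scatter. Among the measured compounds shown here, no step speaks to a 3,5-dimethoxyphenyl, so the expectation rests on the span those two steps cover. A small lowering of the number is expected, a 1.5-fold lower number from compound 1 to compound 4 (0.18 log units; within the scatter), with a real chance that it stays within the scatter. Compound 4 is estimated at 6500 nM in this assay, within a range from 2000 nM to 16000 nM.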

Compound 4, half-maximal inhibitory concentration: 2110 nM
The estimate for compound 4 lay 3.1-fold (0.49 log units) above the measured number; the range from low to high includes it.
By their numbers in this assay, from the lowest: compounds 2 and 4 (each within the scatter of the next); then compounds 3 and 1 (each within the scatter of the next).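

The exchange to 3,5-dimethoxyphenyl on a saturated chain carbon bound to an aromatic nitrogen gives a 4.6-fold lower number from compound 1 to compound 4 (0.67 log units; beyond the scatter) in this assay, so a replacement of 4-cyanophenyl without fluorine, and with 10 heavy atoms against 8, also lowers the number beyond the scatter. Fluorine therefore does not track the level reached at this position: the exchange from 3,4-difluorophenyl gives a 3.4-fold lower number from compound 3 to compound 4 (0.54 log units; beyond the scatter), while the exchange from 2-fluorophenyl gives a 1.7-fold higher number from compound 2 to compound 4 (0.23 log units; within the scatter), which leaves compound 2 and compound 4 unseparated, and compound 3 remains the one aryl exchange that goes against a lowering relative to compound 1. Nothing at hand accounts for why these aryl groups differ in this way.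

Open, on these data alone, is whether a phenyl carrying a single methoxy group keeps the level of compound 4, which would show if one methoxy group is enough at this place. Equally open, as far as these compounds go, is how an amine on the phenyl ring, or a longer chain joining the phenyl ring to the aromatic nitrogen, would fare in this assay.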